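This account rests on a few compounds, and the source may have more. Where it says the series, first, only, none or still open, it means among the compounds named here.

Working notes on the series. Compound 1 `Cc1cc(Cl)ccc1Oc1ccncc1CN(C)C` gives 3230 nM in an assay on HEK293 cells for inhibition of sodium-dependent dopamine transporter (Homo sapiens); a lower number here means a stronger inhibitor, a higher number a weaker inhibitor. For the measured compounds named here, compound 2 `CN(C)Cc1cnccc1Oc1ccc(Cl)cc1Br` gives 1970 nM in this assay; the step of a 1.6-fold lower number from compound 1 to compound 2 (0.21 log units; within the scatter) is the only one between measured compounds. Compound 3 `CNCc1cnccc1Oc1ccc(Cl)cc1Cl` gives "not determined" (no result reported) in this assay, so it stands nowhere on the numbers shown. Compound 4 `CN(C)Cc1cnccc1Oc1ccc(Cl)cc1Cl` differs from compound 3 by methyl in place of hydrogen on an amine nitrogen. Going by the values given here, no measured step bears on this change: the step from compound 1 to compound 2 concerns a substituent on an aromatic carbon, not the amine nitrogen, and compound 3 itself has no value to start from. Compound 4 carries the same dimethylamino group as compound 1 and compound 2, whose values in this assay lie close together, and is therefore expected near 2200 nM, with a range of 700 nM to 7000 nM.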

Compound 4, half-maximal inhibitory concentration: 2430 nM
The estimate for compound 4 lay 1.1-fold (0.04 log units) below the measured number, within the range that was stated.
By their numbers in this assay, from the lowest: compounds 2, 4 and 1 (each within the scatter of the next).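

The step on the amine nitrogen cannot be read, since compound 3 has no number in this assay, so methylamino to dimethylamino remains without a measured effect. On the aromatic carbon, with dimethylamino held constant, chloro now stands within the scatter of both bromo (a 1.2-fold higher number from compound 2 to compound 4 (0.09 log units; within the scatter)) and methyl (a 1.3-fold lower number from compound 1 to compound 4 (0.12 log units; within the scatter)), so the three groups are not separated here. No available evidence accounts for this result.

Open, on these data alone, is whether a methoxy or trifluoromethyl group on that aromatic carbon would separate from these three. Also open, as far as these compounds go, is whether a primary amine or a pyrrolidine in place of dimethylamino would change the number.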